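The source may report more compounds than this note shows. Statements on the series, on what has been measured and on what is new or still open speak of the compounds shown alone.

Three compounds share one core in an in vitro functional assay on cells for agonist activity at Bombesin receptor subtype-3 (Homo sapiens), read by luminescence and calcium flux; a lower number here means that less compound is needed, a higher number that more compound is needed for the effect. Compound 1 `O=C(O)c1ccccc1-c1ccc(CCc2ncc(CCC3CCCCC3)[nH]2)cc1` gives 642 nM, compound 2 `O=C(O)c1ccccc1-c1ccc(CCc2ncc(CC3CCOCC3)[nH]2)cc1` gives 338 nM, and compound 3 `CC(C)(C)c1cnc(CCc2ccc(-c3ccccc3C(=O)O)cc2)[nH]1` gives 4330 nM. Compound 3 stands highest of the three, with a 6.7-fold higher number from compound 1 to compound 3 (0.83 log units; beyond the scatter) and a 13-fold higher number from compound 2 to compound 3 (1.11 log units; beyond the scatter), whereas the step of a 1.9-fold lower number from compound 1 to compound 2 (0.28 log units; within the scatter) is small. The unmeasured compound 4 `O=C(O)c1ccccc1-c1ccc(CCc2ncc(Cc3ccccc3)[nH]2)cc1` differs from compound 3 in one place: benzyl in place of tert-butyl on an aromatic carbon. For the measured compounds named here, two measured steps bear on this change. In both, replacing a larger group on that aromatic carbon with tert-butyl raised the number, modestly in a 6.7-fold higher number from compound 1 to compound 3 (0.83 log units; beyond the scatter) and by a large margin in a 13-fold higher number from compound 2 to compound 3 (1.11 log units; beyond the scatter). Benzyl is again a larger group than tert-butyl, though it brings a six-membered aromatic ring that neither compound 1 nor compound 2 carries, so no measured step matches it exactly. On this basis compound 4 is expected to give a lower number than compound 3, with an estimated step of a 4.8-fold lower number from compound 3 to compound 4 (0.68 log units; beyond the scatter). Compound 4 is therefore estimated at 900 nM, with a range from 300 nM to 3000 nM.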

Compound 4, half-maximal effective concentration: 205 nM
Estimate against measurement, compound 4: 4.4-fold (0.64 log units) above; measured number below the stated range.
By their numbers in this assay, from the lowest: compounds 4, 2 and 1 (each within the scatter of the next, the first and the last beyond it); then compound 3.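

In this assay, benzyl on this aromatic carbon, next to the ring nitrogen, gives a 21-fold lower number from compound 3 to compound 4 (1.32 log units; beyond the scatter), showing that a low number at this position does not require the rings of compound 1 or compound 2, since a six-membered aromatic ring of carbon only serves here as well. With phenyl in place of oxan-4-yl on the saturated chain carbon, the result is a 1.6-fold lower number from compound 2 to compound 4 (0.22 log units; within the scatter), while phenyl in place of cyclohexylmethyl gives a 3.1-fold lower number from compound 1 to compound 4 (0.50 log units; beyond the scatter). No measurement shown here offers an explanation for these steps.

The compounds shown leave open how a chlorine or a methoxy group on the phenyl ring would read in this assay. They also leave open what a 2-phenylethyl group or an amine on the chain would do at this position.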